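Swapping a Bromo for a Fluoro on an Indole Ring

This account rests on a few compounds, and the source may have more. Where it says the series, first, only, none or still open, it means among the compounds named here.

Measured compounds:
compound 1 `COc1ccc2[nH]cc(-c3nc(C(=O)Nc4cc(OC)c(OC)c(OC)c4)cs3)c2c1` gives 9980 nM in a functional assay on HeLa cells (Homo sapiens) for cytotoxicity, read by MTT assay, with a stated time of 48 h, in the presence of a further agent that is not named here; on this read-out higher numbers stand for weaker inhibition and lower numbers for stronger inhibition
compound 2 `COc1cc(NC(=O)c2csc(-c3c[nH]c4ccc(Br)cc34)n2)cc(OC)c1OC` gives 93000 nM in this assay

Compound 2 stands highest of the two numbers; its nearest neighbour is compound 1, and the step of a 9.3-fold higher number from compound 1 to compound 2 (0.97 log units; beyond the scatter) separates them. Compound 3 `COc1cc(NC(=O)c2csc(-c3c[nH]c4ccc(F)cc34)n2)cc(OC)c1OC` differs from compound 2 by fluoro in place of bromo on an aromatic carbon. For the measured compounds named here, no measured step covers a halogen-for-halogen swap; the only step at hand shows that replacing methoxy by bromo raised the number, so fluoro may land between the two measured values. Compound 3 is therefore expected to give a modestly lower number, a 3.1-fold lower number from compound 2 to compound 3 (0.49 log units; beyond the scatter), estimated at 30000 nM with a range from 10000 nM to 90000 nM.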

Compound 3, half-maximal inhibitory concentration: 48900 nM
The estimate for compound 3 lay 1.6-fold (0.21 log units) below the measured number; low and high end bracket the measured number.
By their numbers in this assay, from the lowest: compound 1; then compounds 3 and 2 (each within the scatter of the next).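

In this assay, fluoro in place of bromo on this aromatic carbon gives a 1.9-fold lower number from compound 2 to compound 3 (0.28 log units; within the scatter) and so leaves the two halogens indistinguishable at this position. Methoxy, by contrast, stays clearly apart from fluoro, as it did from bromo, with a 4.9-fold higher number from compound 1 to compound 3 (0.69 log units; beyond the scatter) at this same position. Nothing at hand explains why these groups compare as they do. As far as these compounds go, how an amine, a hydroxyl or a chloro group would read on this carbon remains open. So does whether fluoro and bromo would also match on a different core.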